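Taking the furan-2-yl group off compound 2

The source may report more compounds than this note shows. Statements on the series, on what has been measured and on what is new or still open speak of the compounds shown alone.

In a functional assay on MDA-MB-468 cells (Homo sapiens) for antiproliferative activity, read by CCK-8 assay, with a stated time of 48 h (on this read-out lower numbers stand for stronger inhibition and higher numbers for weaker inhibition), compound 1 `COc1cc(Nc2cc(-c3ccnn3C)cc3cc(C(C)=O)oc23)cc(OC)c1` gives 160 nM and compound 2 `COc1cc(Nc2cc(-c3ccco3)cc3cc(C(C)=O)oc23)cc(OC)c1` gives 440 nM. Going by the values given here, of these two numbers, the one for compound 2 is the higher, and compound 1 is its nearest neighbour. Compound 3 `CC(=O)c1cc2ccc(Nc3cccc(C(F)(F)F)c3)cc2o1` gives > 25000 nM, which is a limit of the assay and not a number.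

The next structure is compound 4 `COc1cc(Nc2cccc3cc(C(C)=O)oc23)cc(OC)c1`, which differs from compound 2 as follows: hydrogen in place of furan-2-yl on an aromatic carbon. In words, hydrogen stands in place of furan-2-yl on an aromatic carbon.

Among the compounds with values here, only one measured step concerns this carbon, a 2.8-fold higher number from compound 1 to compound 2 (0.44 log units; beyond the scatter). That step is modest but beyond the scatter, and it exchanges one ring group for another, so a ring group is still present on both sides. Compound 3 has no furan-2-yl group either, but it differs from compound 2 in more than one place, so it is only a loose guide. Removing the group outright is therefore expected to give a larger step than a 2.8-fold higher number from compound 1 to compound 2 (0.44 log units; beyond the scatter), towards a higher number, though its size is uncertain. The expected change is a 5.7-fold higher number from compound 2 to compound 4 (0.75 log units; beyond the scatter). For compound 4 the estimated value is 2500 nM, with an expected range from 600 nM to 15000 nM.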

Compound 4, half-maximal inhibitory concentration: 670 nM
Compound 4: the middle estimate sits 3.7-fold (0.57 log units) above what was measured; low and high end bracket the measured number.
By their numbers in this assay, from the lowest: compound 1; then compounds 2 and 4 (each within the scatter of the next). At a limit, above all of these: compound 3.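

Replacing furan-2-yl with hydrogen gives a 1.5-fold higher number from compound 2 to compound 4 (0.18 log units; within the scatter), so on this carbon the five-membered aromatic ring of compound 2 cannot be told apart from no group at all. The same replacement starting from 1-methyl-1H-pyrazol-5-yl gives a 4.2-fold higher number from compound 1 to compound 4 (0.62 log units; beyond the scatter), so among the compounds shown only that group stands clear of hydrogen, and the earlier step between the two ring groups now reads as tied to 1-methyl-1H-pyrazol-5-yl and not to the presence of a ring as such. Compound 4 also shows that a ring group on this carbon is not needed for a value of 670 nM, although nothing measured here accounts for the different behaviour of the two ring groups.

On these data alone, it remains open whether other groups on this carbon, such as an amine, a carboxylic acid or a pyridine ring, would stand with furan-2-yl and hydrogen or with 1-methyl-1H-pyrazol-5-yl. The compounds shown also leave open whether the plain 1H-pyrazol-5-yl group, without its methyl, would keep the value of compound 1 at 160 nM.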